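The compounds below may be only part of what the source reports. "The series", "measured", "known", "first", "only" and "open" are said of these compounds alone.

In an ADME assay on cells (Peritoneal macrophage, Mus musculus) for cytotoxicity, read by CCK-8 assay, with a stated time of 24 h (a lower number here means that less compound is tolerated, a higher number that more compound is tolerated), compound 1 `COc1ccc(S(=O)(=O)N(CC(N)=O)c2ccc(N(CC(N)=O)S(=O)(=O)c3ccc(SCCCCCN=C=S)cc3)c3ccccc23)cc1` gives > 10000 nM, which is a limit of the assay and not a number. Compound 2 `COc1ccc(S(=O)(=O)N(CC(N)=O)c2ccc(N(CC(N)=O)S(=O)(=O)c3ccc(S(=O)(=O)CCCCN=C=S)cc3)c3ccccc23)cc1` gives > 10000 nM, also a limit and not a number. Compound 3 `COc1ccc(S(=O)(=O)N(CC(N)=O)c2ccc(N(CC(N)=O)S(=O)(=O)c3ccc(S(=O)(=O)CCCCCN=C=S)cc3)c3ccccc23)cc1` differs from compound 2 in one place: a group of 4 heavy atoms (2 carbon, 1 nitrogen, 1 sulfur; no ring) in place of a group of 3 heavy atoms (1 carbon, 1 nitrogen, 1 sulfur; no ring), on a saturated chain carbon, four bonds along the chain from a sulfonyl sulfur. Going by the values given here, only one measured step bears on this change, namely a step that the two limits leave unreadable from compound 1 to compound 2. Its size cannot be read, so it offers no guide to size or direction. Compound 2 sits at the limit of > 10000 nM in this assay, at which 2 of the 2 values shown sit, so no step beyond the scatter is expected in this assay for compound 3. The expected step is a step that the limit leaves unreadable from compound 2 to compound 3, which is an estimate only. For compound 3 the estimated value is 12000 nM, with an expected range from 5000 nM to 30000 nM.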

Compound 3, half-maximal cytotoxic concentration: > 10000 nM
Compound 3 was reported as a limit; the forecaster's own chance of this, stated with the estimate: 80%; the middle value lies beyond the limit too.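

Going by these compounds alone, no step among compound 1, compound 2 and compound 3 can be read, as each result is a limit and not a number: the limit of > 10000 nM in this assay, at which 3 of the 3 values shown sit. The compounds shown leave open how much of each compound the cells tolerate, and whether the differences between these compounds change that tolerance at all.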